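This account rests on a few compounds, and the source may have more. Where it says the series, first, only, none or still open, it means among the compounds named here.

In an assay on isolated protein (Mus musculus) for inhibition of IL15-IL15 receptor (Homo sapiens), read by resazurin assay, with stated times of 30 min and 2.5 days (on this read-out higher numbers stand for weaker inhibition and lower numbers for stronger inhibition), compound 2 `CC(C)Oc1ccc(NC(=O)CCCCCCCSc2nnc(Cc3nn(C)c(=O)c4ccccc34)n2C)cc1` gives 1100 nM. That is the lower of the two numbers reported so far; compound 1 `Cn1c(Cc2nn(C)c(=O)c3ccccc23)nnc1SCCCCCCCCCCC(=O)Oc1ccc(Cl)cc1Cl` gives 8700 nM, a higher number that lies beyond the usual scatter of repeated measurements. Compound 3 `Cn1c(Cc2nn(C)c(=O)c3ccccc23)nnc1SCC(=O)Nc1ccc(I)cc1` gives "not active" (no number reported), and no number was reported for it. Compound 4 `Cc1ccc(NC(=O)CCCCCCCSc2nnc(Cc3nn(C)c(=O)c4ccccc34)n2C)c(Cl)c1` has not yet been measured. It differs from compound 2 in one place: 2-chloro-4-methylphenyl in place of 4-isopropoxyphenyl on an amide-type nitrogen. For the measured compounds named here, no pair of measured compounds shows this kind of change, so the expectation rests on compound 2 alone. The change is expected to make little difference, and the step of a 1.4-fold higher number from compound 2 to compound 4 (0.13 log units; within the scatter) is expected to stay within or close to the scatter. Compound 4 is therefore estimated at 1500 nM, with a range from 500 nM to 5000 nM.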

Compound 4, half-maximal inhibitory concentration: 2300 nM
For compound 4 the middle estimate is 1.5-fold (0.19 log units) below the measured one; the measured number falls inside the stated range.
By their numbers in this assay, from the lowest: compound 2; then compound 4; then compound 1.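

In this assay, for the compounds shown here, the swap of 4-isopropoxyphenyl for 2-chloro-4-methylphenyl on the amide-type nitrogen gives a 2.1-fold higher number from compound 2 to compound 4 (0.32 log units; beyond the scatter) and so gives the first direct reading at this position. A different substituted phenyl is tolerated here with a modest loss, only just beyond the usual scatter. Nothing at hand explains this shift. Several groups change at once, so the separate shares of the chlorine, the methyl and the isopropoxy stay open. Also open, on these data alone, is how a plain phenyl, or a phenyl carrying an amine or a carboxylic acid, would fare on this nitrogen.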